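A few compounds are considered here, and "the series" means these few. Any claim that something is new, unique, unknown or untested is made for them only; others in the source may bear on it.

In an ADME assay on BHK cells (Mesocricetus auratus) for cytotoxicity, read by MTT assay, with a stated time of 96 h (a lower number here means that less compound is tolerated, a higher number that more compound is tolerated), compound 2 `CCN(CC)CC(=O)Nc1ccc(-c2nc3cc(C(F)(F)F)ccc3n2C)cc1` gives 16000 nM. It stands level with compound 1 `CN1CCN(CC(=O)Nc2ccc(-c3nc4cc(C(F)(F)F)ccc4n3C)cc2)CC1`, which in this assay gives 16000 nM; the step of no change at the digits printed from compound 1 to compound 2 (within the scatter) shows that exchanging one amine for another on that chain left the tolerated concentration where it was. Compound 3 `Cn1c(-c2ccc(N)cc2)nc2cc(C(F)(F)F)ccc21` has not yet been measured in this assay. Its change from compound 2 is hydrogen in place of ((diethylamino)methyl)carbonyl on a nitrogen on an aromatic ring. Among the compounds with values here, the only measured step, from compound 1 to compound 2, concerns a swap within the ((diethylamino)methyl)carbonyl part and not its removal, so it gives weak guidance; since that step was flat, no movement beyond the usual scatter is expected here. Compound 3 is estimated to give 16000 nM, within a range from 6000 nM to 40000 nM. That estimate corresponds to an expected step of no change at the digits printed from compound 2 to compound 3 (within the scatter).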

Compound 3, half-maximal cytotoxic concentration: 85000 nM
Compound 3: the middle estimate sits 5.3-fold (0.73 log units) below what was measured; measured number outside the range, above it.
By their numbers in this assay, from the lowest: compounds 1 and 2 (each within the scatter of the next); then compound 3.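

Taking the whole ((diethylamino)methyl)carbonyl group off the nitrogen on the aromatic ring and leaving hydrogen gives in this assay a 5.3-fold higher number from compound 2 to compound 3 (0.73 log units; beyond the scatter), and doing the same with ((4-methylpiperazin-1-yl)methyl)carbonyl gives a 5.3-fold higher number from compound 1 to compound 3 (0.73 log units; beyond the scatter). Within the data shown here, the earlier swap of one amine for another showed no movement, so this is the first sign that the number responds to a change at this nitrogen, and both side chains give the same result when removed. Nothing measured here explains why the tolerated concentration rises.

Still open, as far as these compounds go, is whether the carbonyl or the amine of the side chain matters more, which an acetyl group on the same nitrogen could help separate. From the compounds shown here alone, it is also open whether a longer chain carrying the diethylamino group would shift the number.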